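Removing the chloro from an inactive trimethoxyphenyl compound

This account rests on a few compounds, and the source may have more. Where it says the series, first, only, none or still open, it means among the compounds named here.

Compound 1 `COc1cc(-c2ncnn2-c2ccc(Cl)cc2Cl)cc(OC)c1OC`: > 10000 nM, a limit
Compound 2 `COc1cc(-n2ncnc2-c2ccc(Cl)cc2)cc(OC)c1OC`: > 10000 nM, a limit
Compound 3 `COc1cc(-c2ncnn2-c2ccccc2)cc(OC)c1OC`: > 10000 nM, a limit

Compound 2 gives > 10000 nM in a functional assay on HeLa cells (Homo sapiens) for antiproliferative activity, read by MTT assay, with a stated time of 72 h (on this read-out higher numbers stand for weaker inhibition and lower numbers for stronger inhibition), and this value is a limit. It offers no number to start from, and the series as a whole looks no different: the limit of > 10000 nM in this assay, at which 3 of the 3 values shown sit.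

Compound 4 `COc1cc(-n2ncnc2-c2ccccc2)cc(OC)c1OC` departs from compound 2 by a single change, (hydrogen in place of chloro on an aromatic carbon). This is hydrogen in place of chloro on an aromatic carbon, so that 4-chlorophenyl becomes phenyl.

For the measured compounds named here, one measured step bears on this change: a step that the two limits leave unreadable from compound 1 to compound 3. It too exchanges a chlorinated phenyl for phenyl, though on an aromatic nitrogen, and it yields no size that could be carried over. No loss of chloro in this series has yet produced a readable value in this assay. No step beyond the scatter is therefore expected, in either direction, and a further limit is the most likely report. The expected change is a step that the limit leaves unreadable from compound 2 to compound 4. For compound 4 the estimated value is 15000 nM, with an expected range from 4000 nM to 50000 nM.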

Compound 4, half-maximal inhibitory concentration: > 10000 nM
Compound 4 gave a limit, no number (the forecaster's own chance of this, stated with the estimate: 85%); the middle value lies beyond the limit too.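

Compound 2 and compound 4 both stand at a limit in this assay, so no size can be read for the step from chloro to hydrogen between them. The compounds shown leave open which change to the shared core, if any, would give a readable value, as the whole series sits at one limit: the limit of > 10000 nM in this assay, at which 4 of the 4 values shown sit.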